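Second Fluorine at the Same Chain Carbon

A few compounds are considered here, and "the series" means these few. Any claim that something is new, unique, unknown or untested is made for them only; others in the source may bear on it.

Three compounds have been measured in a physicochemical assay for lipophilicity, read by NMR; on this read-out lower numbers stand for lower lipophilicity and higher numbers for higher lipophilicity:
compound 1 `OCCC(F)(F)CF` gives 0.27;
compound 2 `OCCC(F)CC(F)(F)F` gives 0.84;
compound 3 `OCCC(F)CF` gives -0.12.

Compound 1 and compound 3 differ in one place: fluoro in place of hydrogen on a saturated chain carbon bound to a fluorine atom and two saturated chain carbons. That single change produced a number 0.39 log units higher from compound 3 to compound 1 (beyond the scatter) in this assay. Compound 2 stands highest of the three numbers; its nearest neighbour is compound 1, and its furthest is compound 3, and both gaps lie beyond the usual scatter. How the core of compound 2 differs from the core of compound 3 is not broken down here.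

Compound 4 `OCCC(F)(F)CC(F)(F)F` has not yet been measured. It differs from compound 2 in one place: fluoro in place of hydrogen on a saturated chain carbon bound to a fluorine atom and two saturated chain carbons. The place is described in the same words for both pairs, so this is the same change as the one from compound 3 to compound 1, now made on the core of compound 2; it occurs twice among the compounds shown.

Within the data shown here, for compound 4 the expected step in this assay is a number 0.41 log units higher from compound 2 to compound 4 (beyond the scatter), resting on a number 0.39 log units higher from compound 3 to compound 1 (beyond the scatter) seen with the only earlier instance of the change. Compound 4 is therefore estimated to give 1.25 in this assay. The expected range for compound 4 runs from 0.95 to 1.55, since the estimate rests on a single earlier step.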

Compound 4, partition coefficient: 1.12
For compound 4 the middle estimate is 0.13 log units above the measured one, within the range that was stated.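

Fluoro in place of hydrogen on a saturated chain carbon bound to a fluorine atom and two saturated chain carbons has now been read on two cores. In this assay the change gave a number 0.28 log units higher from compound 2 to compound 4 (within the scatter) on the core of compound 2, so there it could not be told apart from repeat measurement, whereas the earlier pair gave a number 0.39 log units higher from compound 3 to compound 1 (beyond the scatter) on the core of compound 3. This shows that the change, carried to a second core, did not again give a step clear of the scatter, but it does not show that the change has no effect on that core, that its effect truly differs between the two cores, or that a rule holds beyond these four compounds, and no supporting evidence bears on why the two steps came out as they did.

The compounds shown leave open how the same change would read on a core carrying an amine or a carboxylic acid in place of the hydroxy group, or on a longer chain. They also leave open whether a step on such a core would stand within or beyond the scatter, since two pairs on two closely related cores give no basis for carrying the result that far.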